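This account rests on a few compounds, and the source may have more. Where it says the series, first, only, none or still open, it means among the compounds named here.

Working notes on the series. In a functional assay with Oryctolagus cuniculus as the target (on this read-out lower numbers stand for stronger inhibition and higher numbers for weaker inhibition), compound 1 `C/N=C(/NC)Nc1nc(-c2ccc(OC)cc2)c(-c2ccc(OC)cc2)s1` gives 970 nM. In this assay compound 2 `COc1ccc(-c2nc(/C=C/C(=O)O)sc2-c2ccc(OC)cc2)cc1` returns only a limit, > 100 nM, so it has no numerical position in the series. The next change leads to compound 3 `COc1ccc(-c2nc(CCC(=O)O)sc2-c2ccc(OC)cc2)cc1`: 2-carboxyethyl in place of 2-carboxyethenyl on an aromatic carbon. In words, 2-carboxyethyl stands in place of 2-carboxyethenyl on an aromatic carbon of the five-membered ring, and the rest of the structure stays the same.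

For the measured compounds named here, only one measured step is available, a step that the limit leaves unreadable from compound 1 to compound 2. It involves a different exchange of groups and gives no size to carry over, so the data support no expected direction in this assay. The working expectation is therefore no shift beyond the scatter, though this cannot be checked against a limit. Going by the values given here, the only numerical anchor is compound 1 at 970 nM. The estimated step is a step that the limit leaves unreadable from compound 2 to compound 3. For compound 3 the expected value is 400 nM, with an estimated range from 50 nM to 3000 nM. A result reported only as a limit is also a real possibility.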

Compound 3, half-maximal inhibitory concentration: < 100 nM
Compound 3: a limit, no number; the forecaster's own chance of this, stated with the estimate: 45%; middle value at least 4.0-fold (0.60 log units) from the limit.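

In this assay compound 3, with 2-carboxyethyl on the aromatic carbon of the five-membered aromatic ring, gives only a limit, < 100 nM, and no number. Even so, this position now has its first readable step, an at least 9.7-fold lower number from compound 1 to compound 3 (0.98 log units; beyond the scatter), which shows that a group of 5 heavy atoms ending in a carboxylic acid can stand here with a clearly lower number than the group of 6 heavy atoms in compound 1. The exchange of 2-carboxyethenyl for 2-carboxyethyl keeps the heavy-atom, donor and acceptor counts and takes the double bonds outside aromatic rings from 2 to 1, and it gives a number no higher from compound 2 to compound 3 (the limit leaves the size open), so this change has a direction but no measured size.

Two limits cannot show whether compound 2 and compound 3 lie close together or far apart, so the effect of the double bond in the chain stays unresolved. Also open, on these data alone, is how the read-out responds to a longer chain ending in a carboxylic acid, or to a methyl ester or a primary amide in place of the carboxylic acid on the same chain.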